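A few compounds are considered here, and "the series" means these few. Any claim that something is new, unique, unknown or untested is made for them only; others in the source may bear on it.

Three measured compounds:
Compound 1 `N#C/C=C/c1cc(F)c(Oc2nc(Nc3ccc(C#N)c(F)c3)nc3sccc23)c(F)c1` gives 117000 nM in a toxicity assay on MT4 cells (Homo sapiens) for cytotoxicity, read by MTT assay, with a stated time of 5 days; on this read-out lower numbers stand for higher toxicity in this test and higher numbers for lower toxicity in this test.
Compound 2 `N#C/C=C/c1cc(F)c(Oc2nc(Nc3ccc(C#N)nc3)nc3sccc23)c(F)c1` gives 12800 nM in this assay.
Compound 3 `Cc1cc(-c2ccc(F)cc2)cc(C)c1Oc1nc(Nc2ccc(C#N)c(F)c2)nc2sccc12` gives 28900 nM in this assay.

Compounds 1 and 2 share a core and differ in one place: 6-cyanopyridin-3-yl in place of 4-cyano-3-fluorophenyl on a nitrogen on an aromatic ring. That change brought a 9.1-fold lower number from compound 1 to compound 2 (0.96 log units; beyond the scatter), so compound 2 is the more toxic of the pair in this assay. Compound 3 carries a different core; the difference between the two cores is not broken down here. Compound 4 `Cc1cc(-c2ccc(F)cc2)cc(C)c1Oc1nc(Nc2ccc(C#N)nc2)nc2sccc12` has not yet been measured; it stands to compound 3 as compound 2 stands to compound 1, through the same change, (6-cyanopyridin-3-yl in place of 4-cyano-3-fluorophenyl on a nitrogen on an aromatic ring). Within the data shown here, the surroundings of the change read the same in both pairs, so the one measured step is the only guide, yet it was seen just once and on another core. A step of the same direction and roughly similar size is therefore expected from compound 3 to compound 4, namely a 7.2-fold lower number from compound 3 to compound 4 (0.86 log units; beyond the scatter), with wide uncertainty because a 9.1-fold lower number from compound 1 to compound 2 (0.96 log units; beyond the scatter) rests on a single pair. Compound 4 is thus estimated at 4000 nM in this assay, with a plausible range from 1500 nM to 15000 nM.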

Compound 4, half-maximal cytotoxic concentration: 2230 nM
Estimate against measurement, compound 4: 1.8-fold (0.25 log units) above; the measured number falls inside the stated range.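

In this assay, putting 6-cyanopyridin-3-yl in place of 4-cyano-3-fluorophenyl brought a 13-fold lower number from compound 3 to compound 4 (1.11 log units; beyond the scatter), so compound 4 is the more toxic of this pair, just as compound 2 is the more toxic of the first pair. Among these compounds, the change therefore carried from one core to the other in direction and, as far as the scatter allows, in size: the same change on two cores in this assay, a 9.1-fold lower number (0.96 log units; beyond the scatter) from compound 1 to compound 2 and a 13-fold lower number (1.11 log units; beyond the scatter) from compound 3 to compound 4, 1.4-fold (0.15 log units) apart, within the scatter of two such steps Still, these are only two cores and two pairs, so this does not show that the step would hold on any other core, and it does not explain why the number falls.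

The compounds shown leave open how the number would move if the nitrile of 6-cyanopyridin-3-yl gave way to a carboxylic acid or an amine. They also leave open what a chlorine in place of the fluorine of 4-cyano-3-fluorophenyl would do in this assay.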